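This account rests on a few compounds, and the source may have more. Where it says the series, first, only, none or still open, it means among the compounds named here.

Measured so far in a functional assay on MDA-MB-231 cells (Homo sapiens) for inhibition, read by MTT assay, with a stated time of 24 h, tested at 100 uM; on this read-out higher numbers stand for more inhibition at the one concentration tested (going by the name of the read-out) and lower numbers for less inhibition:

compound 1, `N#Cc1cccc(/C=N/NC(=O)c2ccc(O[C@@H]3O[C@H](CO)[C@@H](O)[C@H](O)[C@H]3O)cc2)c1`, gives 6.17%;
compound 2, `O=C(N/N=C/c1ccc(Cl)cc1)c1ccc(O[C@@H]2O[C@H](CO)[C@@H](O)[C@H](O)[C@H]2O)cc1`, gives 2.26%;
compound 3, `CC(=O)OC[C@H]1O[C@@H](Oc2ccc(-c3nnc(C(C)C)o3)cc2)[C@H](OC(C)=O)[C@@H](OC(C)=O)[C@@H]1OC(C)=O`, gives 11.9%.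

On these numbers compound 2 stands together with the other two: its gap to compound 1 and its gap to compound 3 each lie within the usual scatter, so none of the three is separated from the others, and all show little inhibition at the one concentration tested.

Compound 4, `CCCCC/C=N/NC(=O)c1ccc(O[C@@H]2O[C@H](CO)[C@@H](O)[C@H](O)[C@H]2O)cc1`, has not yet been measured in this assay . It differs from compound 2 in one place: pentyl in place of 4-chlorophenyl on a carbon with a double bond to nitrogen.

For the measured compounds named here, the only measured step that bears on this position is the one from compound 1 to compound 2, where one aryl group replaced another on the same carbon and the result was a number 3.9 percentage points lower from compound 1 to compound 2 (within the scatter). Going by the values given here, that step says nothing about an open chain entering at this position, so the expectation rests on the small size of the one change seen there. Compound 4 is therefore expected to give a number close to that of compound 2, with a step of a number 2.7 percentage points higher from compound 2 to compound 4 (within the scatter) that is not expected to exceed the scatter. The estimate for compound 4 in this assay is 5%, between 0% and 15%.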

Compound 4, a percentage reported as inhibition, at one concentration (the size of the read-out at that concentration, not a potency): 11%
Compound 4: the middle estimate sits 6 percentage points below what was measured; the range from low to high includes it.
By their numbers in this assay, from the lowest: compounds 2, 1, 4 and 3 (each within the scatter of the next).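

Until this point only aryl groups had stood on the carbon with a double bond to nitrogen; compound 4 carries an open chain there, pentyl, which has no ring and fewer heavy atoms than the 4-chlorophenyl it replaces. In this assay this exchange gives a number 8.7 percentage points higher from compound 2 to compound 4 (within the scatter), and the exchange for the 3-cyanophenyl group gives a number 4.8 percentage points higher from compound 1 to compound 4 (within the scatter), so among these three compounds neither aryl group stands apart from the open chain, and all three show little inhibition at the one concentration tested. No measurement at hand offers an explanation for these small differences.

It remains open whether any group on this carbon can move the read-out clear of the scatter, since an amine or a carboxylic acid at the end of the chain, a longer chain such as decyl and a shorter one such as methyl have no counterpart among the compounds shown. Compound 3 differs from the others in more than one place, so it cannot be compared with them directly, and what its acetate esters and its replacement of the hydrazone linkage each contribute also stays unresolved.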